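The source may hold more compounds than are shown below. What is called first, only, known or untested is meant among the compounds shown, and "the series" means these compounds.

Compound 1 `FC(F)(F)c1ccc(CN2CCN(Cc3cc(-c4ccc(OCc5ccc(Cl)cc5)cc4)on3)CC2)cc1` and compound 2 `Fc1ccccc1COc1ccc(-c2cc(CN3CCN(Cc4ccc(C(F)(F)F)cc4)CC3)no2)cc1` share one core and differ only in the group on a saturated chain carbon bound to an oxygen on an aromatic ring. In a functional assay on MCF7 cells (Homo sapiens) for antiproliferative activity, read by sulforhodamine B assay, with a stated time of 72 h (a higher number here means a weaker inhibitor, a lower number a stronger inhibitor), compound 1 gives 6700 nM, while compound 2 gives 3000 nM. The step of a 2.2-fold lower number from compound 1 to compound 2 (0.35 log units; beyond the scatter) is modest. Going by the values given here, compound 2 thus holds the lowest of the two numbers measured so far in this assay. Compound 3 `Fc1cccc(COc2ccc(-c3cc(CN4CCN(Cc5ccc(C(F)(F)F)cc5)CC4)no3)cc2)c1` follows the same line: 3-fluorophenyl in place of 2-fluorophenyl on a saturated chain carbon bound to an oxygen on an aromatic ring. Among the compounds with values here, the one measured step that touches this position is the one between compound 1 and compound 2, in which the whole ring substituent was exchanged. Moving a single fluorine within the ring is expected to give a step of a 1.1-fold higher number from compound 2 to compound 3 (0.03 log units; within the scatter) that stays within the scatter, given that a 2.2-fold lower number from compound 1 to compound 2 (0.35 log units; beyond the scatter) was itself only modest. The estimate for compound 3 in this assay is therefore 3200 nM, with a range from 1500 nM to 7000 nM.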

Compound 3, half-maximal inhibitory concentration: 2500 nM
Estimate against measurement, compound 3: 1.3-fold (0.11 log units) above; the measured number falls inside the stated range.
By their numbers in this assay, from the lowest: compounds 3 and 2 (each within the scatter of the next); then compound 1.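

In this assay, 3-fluorophenyl in place of 2-fluorophenyl gives a 1.2-fold lower number from compound 2 to compound 3 (0.08 log units; within the scatter) and so leaves the two fluorophenyl compounds indistinguishable at this position on a saturated chain carbon bound to an oxygen on an aromatic ring. The other new step, 3-fluorophenyl in place of 4-chlorophenyl, gives a 2.7-fold lower number from compound 1 to compound 3 (0.43 log units; beyond the scatter) and is modest, so the modest separation from the 4-chlorophenyl compound now holds for both fluorophenyl groups. No measurement is at hand that could explain these numbers.

The compounds shown leave open whether the separation from compound 1 follows the halogen or its place on the ring, a question that a 4-fluorophenyl or a 3-chlorophenyl group would address. They also do not show how an unsubstituted phenyl group or a 3-methoxyphenyl group would read here.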